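Acetyl on the ring nitrogen: compound 1 to compound 4

The source may report more compounds than this note shows. Statements on the series, on what has been measured and on what is new or still open speak of the compounds shown alone.

Measured so far in a functional assay on HepG2 cells (Homo sapiens) for cytotoxicity, read by sulforhodamine B assay, with a stated time of 48 h; a lower number here means a stronger inhibitor, a higher number a weaker inhibitor:
compound 1, `COc1ccc(/C=C/C(=O)c2ccc(N)c(-c3ccc(F)cc3)c2)cc1OC`: 3780 nM
compound 2, `COc1ccc(/C=C/C(=O)c2cccc(-c3cccc(F)c3)c2)cc1O`: "not determined" (no result reported)
compound 3, `COc1ccc(-c2cc(C(=O)/C=C/c3cccc(OC)c3OC)ccc2N)cc1OC`: 5360 nM

Compound 1 holds the lowest of the two numbers available, but compound 3 sits within the scatter of it, so neither can be called the stronger inhibitor. Compound 2 has no result and gives no bearing here.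

The next compound, compound 4, `COc1ccc(/C=C/C(=O)c2ccc(NC(C)=O)c(-c3ccc(F)cc3)c2)cc1OC`, differs from compound 1 in one place: acetyl in place of hydrogen on a nitrogen on an aromatic ring. Cut one bond further out, the change reads amino to acetamido.

Among the measured compounds shown here, no pair of measured compounds shows a matching step, so there is no anchor for its size. With nothing in the series to argue for a move either way, the expectation is a step no larger than the scatter, with a slight lean towards a higher number, and the step from compound 1 to compound 4 is estimated at a 1.3-fold higher number from compound 1 to compound 4 (0.12 log units; within the scatter). Compound 4 is therefore expected to give about 5000 nM, within 1500 nM to 16000 nM.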

Compound 4, half-maximal inhibitory concentration: 5630 nM
Estimate against measurement, compound 4: 1.1-fold (0.05 log units) below; low and high end bracket the measured number.
By their numbers in this assay, from the lowest: compounds 1, 3 and 4 (each within the scatter of the next).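

In this assay, among the compounds shown here, acetyl in place of hydrogen on a nitrogen on an aromatic ring gives a 1.5-fold higher number from compound 1 to compound 4 (0.17 log units; within the scatter), the first single-place step. This position therefore carries the acetyl group without a step beyond the scatter, and in this one pair the free amino group is not shown to be required for the read-out. Nothing available accounts for the size of this step.

Still open, on these data alone, is whether a longer acyl chain such as propionyl, a methanesulfonyl group or a dimethylamino group on this nitrogen would also stay within the scatter of compound 1. Also open, as far as these compounds go, is whether acetyl on the nitrogen of compound 3 would give a step of similar size on that core.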